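A methyl in place of a fluoro

The source may hold more compounds than are shown below. What is called first, only, known or untested is meant among the compounds shown, and "the series" means these compounds.

- compound 1 `Cc1ccc2c(c1)/C(=C1/Nc3ccccc3/C1=N\O)C(=O)N2Cc1ccc(/C=C/C(=O)NO)cc1` gives 60 nM
- compound 2 `O=C(NO)c1ccc(CN2C(=O)/C(=C3\Nc4ccccc4\C3=N/O)c3cc(Cl)ccc32)cc1` gives 50 nM
- compound 3 `O=C(NO)c1ccc(CN2C(=O)/C(=C3\Nc4ccccc4\C3=N/O)c3cc(F)ccc32)cc1` gives 50 nM

All three values come from a functional assay on PC-3 cells (Homo sapiens) for cytotoxicity, read by colorimetric assay (on this read-out lower numbers stand for stronger inhibition and higher numbers for weaker inhibition), where compound 3 stands level with compound 2 and within the scatter of compound 1. Compound 4 `Cc1ccc2c(c1)/C(=C1/Nc3ccccc3/C1=N\O)C(=O)N2Cc1ccc(C(=O)NO)cc1` differs from compound 3 by one change, (methyl in place of fluoro on an aromatic carbon), methyl in place of fluoro on an aromatic carbon. For the measured compounds named here, the one measured step at that carbon, no change at the digits printed from compound 2 to compound 3 (within the scatter), put fluoro in place of chloro and stayed within the scatter. Compound 1, with methyl there but differing elsewhere too, gives 60 nM within the scatter of compound 3. No shift beyond the scatter is therefore expected in this assay, and the expected 1.1-fold higher number from compound 3 to compound 4 (0.04 log units; within the scatter) is small. The estimate for compound 4 is 55 nM with 25 nM to 120 nM as the expected range.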

Compound 4, half-maximal inhibitory concentration: 90 nM
Beside the measured number, compound 4's estimate is 1.6-fold (0.21 log units) below it, within the range that was stated.
By their numbers in this assay, from the lowest: compounds 2, 3, 1 and 4 (each within the scatter of the next).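

In this assay, methyl at this aromatic carbon reads like fluoro (a 1.8-fold higher number from compound 3 to compound 4 (0.26 log units; within the scatter)) and like chloro (a 1.8-fold higher number from compound 2 to compound 4 (0.26 log units; within the scatter)), both steps within the scatter. For the compounds shown here, the new compound also gives the first single-place comparison at the other end of the molecule, where hydroxycarbamoyl in place of 2-(hydroxycarbamoyl)ethenyl stays within the scatter too (a 1.5-fold higher number from compound 1 to compound 4 (0.18 log units; within the scatter)). Nothing available explains these readings.

From the compounds shown here alone, whether an amine or a carboxylic acid at this aromatic carbon would also stay within the scatter remains open. So does the outcome of a longer chain carrying the hydroxycarbamoyl group.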